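Chain variations on the shared core in mice

The source may report more compounds than this note shows. Statements on the series, on what has been measured and on what is new or still open speak of the compounds shown alone.

Measured compounds in a functional assay on the whole organism (strain ICR) for inhibition, with Mus musculus as the target, with a stated time of 16 h, at a dose of 10 mg/kg by the oral route; a lower number here means less inhibition, a higher number more inhibition at the dose given (going by the name of the read-out):
- compound 1 `CC(C)S(=O)(=O)CCC12CCC(c3nnc(-c4ccccc4C(F)(F)F)n3C)(CC1)CC2` gives 59%
- compound 2 `Cn1c(-c2ccccc2C(F)(F)F)nnc1C12CCC(COc3ccc(S(C)(=O)=O)cc3)(CC1)CC2` gives 28%
- compound 3 `CCOCC12CCC(c3nnc(-c4ccccc4C(F)(F)F)n3C)(CC1)CC2` gives 3%

Compound 3 stands lowest of the three numbers in this assay; its nearest neighbour is compound 2, and the furthest is compound 1, both beyond the scatter above it. The two steps that reach compound 3 both fall: a number 56 percentage points lower from compound 1 to compound 3 (beyond the scatter) and a number 25 percentage points lower from compound 2 to compound 3 (beyond the scatter). Between the other pair, a number 31 percentage points lower from compound 1 to compound 2 (beyond the scatter).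

Compound 4 `CC(F)CCCC12CCC(c3nnc(-c4ccccc4C(F)(F)F)n3C)(CC1)CC2` is not yet measured. It differs from compound 3 as follows: 3-fluorobutyl in place of ethoxy on a saturated chain carbon bound to a saturated ring carbon. The group that enters is 3-fluorobutyl, a chain without oxygen, whereas every measured change so far has exchanged groups at the same place that carry a sulfonyl or an ether oxygen. Within the data shown here, no measured step exchanges one plain chain for another, so the bearing of the steps from compound 1 and compound 2 is indirect: they show only that the number at this place is higher with a larger group there, highest when that group is the (isopropylsulfonyl)methyl of compound 1. A small rise from the floor is therefore expected, a number 12 percentage points higher from compound 3 to compound 4 (beyond the scatter), but with wide uncertainty. Compound 4 is estimated at 15%, within 0% to 45%.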

Compound 4, a percentage reported as inhibition, in the whole organism at one dose (the size of the read-out at that dose, not a potency): 51%
Compound 4: middle estimate off by 36 percentage points, on the low side; measured number outside the range, above it.
By their numbers in this assay, from the lowest: compound 3; then compound 2; then compounds 4 and 1 (each within the scatter of the next).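

In this assay, the low number of compound 3 can no longer be read as a general result for groups without a sulfonyl at this place: a number 48 percentage points higher from compound 3 to compound 4 (beyond the scatter) with 3-fluorobutyl in place of ethoxy, a change that leaves the chain with no oxygen and no hydrogen-bond acceptor. A sulfonyl is not required for a high number among these four compounds, and its presence does not ensure one, as a number 23 percentage points higher from compound 2 to compound 4 (beyond the scatter) when 3-fluorobutyl replaces 4-(methylsulfonyl)phenoxy on a saturated chain carbon bound to a saturated ring carbon. Compared with the sulfone of compound 1, a number 8 percentage points lower from compound 1 to compound 4 (within the scatter) when 2-fluoropropyl replaces isopropylsulfonyl, so these two very different chain ends cannot be told apart in this assay.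

The compounds shown leave open whether the fluorine or the all-carbon chain accounts for the rise from compound 3, a question that a plain butyl chain or a longer chain at the same place would address. Nothing available here gives a reason for these steps.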